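Removing a Ring Fluorine: From Compound 2 to Compound 3

This account rests on a few compounds, and the source may have more. Where it says the series, first, only, none or still open, it means among the compounds named here.

Compound 1 `Nc1nc(N2CCN(C(=O)COc3ccc(Br)cc3)CC2)c2ccsc2n1`: 320 nM
Compound 2 `Cc1cccc(NC(=O)N2CCN(c3nc(N)nc4sc(F)cc34)CC2)c1`: 2800 nM

Of the compounds shown here, two have been measured in a functional assay on cells (Lymphocyte); a lower number here means a stronger inhibitor, a higher number a weaker inhibitor. Compound 1 gives 320 nM. Compound 2 gives 2800 nM, the highest of the two numbers; its nearest neighbour is compound 1, which differs from it in several places at once, so the gap between the two cannot be assigned to any single change. Compound 3 `Cc1cccc(NC(=O)N2CCN(c3nc(N)nc4sccc34)CC2)c1` has not yet been measured. It differs from compound 2 by hydrogen in place of fluoro on an aromatic carbon. For the measured compounds named here, no measured pair shows this change on its own, so its effect in this assay is not known from these data. The step of a 1.3-fold lower number from compound 2 to compound 3 (0.10 log units; within the scatter) is expected to be small, possibly within the scatter, and could go in either direction. The estimate for compound 3 in this assay is 2200 nM, with a range from 700 nM to 7000 nM.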

Compound 3, half-maximal inhibitory concentration: 930 nM
Compound 3: middle estimate off by 2.4-fold (0.37 log units), on the high side; low and high end bracket the measured number.
By their numbers in this assay, from the lowest: compound 1; then compound 3; then compound 2.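

In this assay, for the compounds shown here, this pair isolates the change for the first time: hydrogen in place of fluoro on an aromatic carbon next to the ring sulfur gives a 3.0-fold lower number from compound 2 to compound 3 (0.48 log units; beyond the scatter), so in this pair the fluoro-bearing compound is the weaker inhibitor. Compound 3 also reduces the gap to compound 1 to a single place, where (3-methylphenyl)amino in place of (4-bromophenoxy)methyl on a carbonyl carbon gives a 2.9-fold higher number from compound 1 to compound 3 (0.46 log units; beyond the scatter) on the same read-out. No measurement shown here explains either step.

This single pair leaves open whether other groups on this carbon, such as chloro, methyl or methoxy, would match hydrogen or fluoro. It also leaves open whether fluoro would give a step of similar size and direction alongside the (4-bromophenoxy)methyl group of compound 1.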